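Swapping a Small Sulfur Group for a Piperidine Ring

A few compounds are considered here, and "the series" means these few. Any claim that something is new, unique, unknown or untested is made for them only; others in the source may bear on it.

Of the compounds shown here, three that share one core have been tested in a functional assay on the whole organism with Rattus norvegicus as the target; a higher number here means that more compound is needed for the effect, a lower number that less compound is needed. Compound 1 `N=c1sc2cc(OC(F)(F)F)ccc2n1Cc1ccccc1` carries a phenyl on a saturated chain carbon bound to an aromatic nitrogen. In this assay compound 1 gives only > 10 mg/kg, which is a limit of the assay and not a number (the limit of > 10 mg/kg in this assay, at which 1 of the 3 values shown sits). Compound 2 `CNS(=O)(=O)CCn1c(=N)sc2cc(OC(F)(F)F)ccc21` gives 4 mg/kg in this assay. Compound 3 `C[S+]([O-])Cn1c(=N)sc2cc(OC(F)(F)F)ccc21` gives 2.3 mg/kg, the lower of the two numbers shown, though its gap to compound 2, a 1.7-fold lower number from compound 2 to compound 3 (0.24 log units; within the scatter), lies within the scatter. Replacing the phenyl gave an at least 2.5-fold lower number from compound 1 to compound 2 (0.39 log units; beyond the scatter) and an at least 4.3-fold lower number from compound 1 to compound 3 (0.63 log units; beyond the scatter).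

Compound 4 `N=c1sc2cc(OC(F)(F)F)ccc2n1CCN1CCCCC1` has not yet been measured. The change is a group of 7 heavy atoms (6 carbon, 1 nitrogen; one six-membered non-aromatic ring with 1 hetero atom) in place of a group of 3 heavy atoms (1 carbon, 1 oxygen, 1 sulfur; no ring), on a saturated chain carbon bound to an aromatic nitrogen. The steps from compound 1 bear on this in reverse: a ring comes back where small chain groups had given the lower numbers, although this ring is non-aromatic and holds a nitrogen. A modest rise in the number is therefore expected for compound 4, a 2.0-fold higher number from compound 3 to compound 4 (0.29 log units; within the scatter), with wide uncertainty. Compound 4 is estimated at 4.5 mg/kg, within the range 1.5 mg/kg to 15 mg/kg.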

Compound 4, dose for half-maximal effect: 2 mg/kg
Beside the measured number, compound 4's estimate is 2.3-fold (0.35 log units) above it, within the range that was stated.
By their numbers in this assay, from the lowest: compounds 4, 3 and 2 (each within the scatter of the next). At a limit, above all of these: compound 1.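

In this assay, a ring on this chain does not by itself keep the number high: with the (piperidin-1-yl)methyl group, non-aromatic and holding a nitrogen, in place of phenyl, there is an at least 5.0-fold lower number from compound 1 to compound 4 (0.69 log units; beyond the scatter). This position also accepts a group of 7 heavy atoms as readily as one of 3, with a 1.2-fold lower number from compound 3 to compound 4 (0.06 log units; within the scatter) and a 2.0-fold lower number from compound 2 to compound 4 (0.30 log units; within the scatter), so the piperidine and the two sulfur-bearing groups cannot be told apart here. Compound 1 remains a limit of the assay and not a number: the limit of > 10 mg/kg in this assay, at which 1 of the 4 values shown sits.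

Compound 1 and compound 4 differ in both the ring and the chain carrying it, so a 2-phenylethyl group would show which of the two counts. A cyclohexyl ring or an open diethylamine would test whether the ring nitrogen or the ring itself matters.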